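The compounds below may be only part of what the source reports. "The series", "measured", "known", "first", "only" and "open" are said of these compounds alone.

Compound 1, `CCCC(=O)c1ccc(OCCCCOc2ccc(F)c(C(=O)O)c2)c(C)c1O`, in an assay on HEK293 cells for positive allosteric modulation of metabotropic glutamate receptor 2 (Rattus norvegicus), read by thallium flux, with a stated time of 2.5 min (on this read-out higher numbers stand for larger maximal responses and lower numbers for smaller maximal responses), compound 1 gives 87.5%.
Compound 2, `COC(=O)c1ccc(OCCCCOc2ccc(C(=O)CC(C)C)c(O)c2C)cc1`, gives 16.4%.
Compound 3, `Cc1cc(OCCCCOc2ccc(C(=O)CC(C)C)c(O)c2C)ccc1C(=O)O`, gives 93.3%.

Compound 3 holds the highest of the three numbers, but its gap to compound 1 lies within the usual scatter, so the two cannot be ranked against each other. Only compound 2 sits clearly lower, by a number 76.9 percentage points higher from compound 2 to compound 3 (beyond the scatter), a large step that came with 4-carboxy-3-methylphenyl taking the place of 4-(methoxycarbonyl)phenyl.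

Compound 4, `Cc1c(OCCCCOc2ccc(F)c(C(=O)O)c2)ccc(C(=O)CC(C)C)c1O`, is not yet measured. It differs from compound 3 by 3-carboxy-4-fluorophenyl in place of 4-carboxy-3-methylphenyl on an oxygen on a saturated carbon. No measured step covers this exchange, and the one shown step concerns a different pair of groups. What helps is compound 1, which already carries 3-carboxy-4-fluorophenyl on a closely related core and in this assay compound 1 gives 87.5%, a number near that of compound 3. The change is therefore expected to stay within the scatter, at a number 5.3 percentage points lower from compound 3 to compound 4 (within the scatter). Compound 4 is expected to give 88%, between 70% and 100%.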

Compound 4, largest response reached (reported as percent of maximum), in percent of the reference or control that the assay uses: 84.5%
For compound 4 the middle estimate is 3.5 percentage points above the measured one, within the range that was stated.
By their numbers in this assay, from the lowest: compound 2; then compounds 4, 1 and 3 (each within the scatter of the next).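

On the oxygen on a saturated carbon, 3-carboxy-4-fluorophenyl and 4-carboxy-3-methylphenyl cannot be told apart in this assay, with a number 8.8 percentage points lower from compound 3 to compound 4 (within the scatter) as the step between them. Against 4-(methoxycarbonyl)phenyl at this place, 3-carboxy-4-fluorophenyl gives a number 68.1 percentage points higher from compound 2 to compound 4 (beyond the scatter), so two differently substituted carboxyphenyl groups now both stand clearly above compound 2. At the other end of the molecule, methyl in place of hydrogen on a saturated chain carbon bound to two saturated chain carbons gives a number 3 percentage points lower from compound 1 to compound 4 (within the scatter), so this chain change has no readable effect on the maximal response here.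

Nothing shown gives a reason for these numbers. Going by these compounds, what a tetrazole or a primary amide would give in place of the carboxy group on this ring stays open, as does chlorine in place of the fluorine.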